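The source may report more compounds than this note shows. Statements on the series, on what has been measured and on what is new or still open speak of the compounds shown alone.

Working notes on the disulfide series.

Compound 1 `CSS[C@H]1C[C@H](n2ccc(N)nc2=O)O[C@@H]1CO` opens the set. In a physicochemical assay for pharmacokinetics, at pH 7.2 (on this read-out lower numbers stand for a shorter-lived compound and higher numbers for a longer-lived compound), compound 1 returns only a limit of the assay, < 0.0834 h. Compound 2 `Cc1cn([C@H]2C[C@H](SSC(Cl)(Cl)Cl)[C@@H](CO)O2)c(=O)[nH]c1=O` carries the same disulfide handle on a different nucleoside core. In this assay compound 2 also returns only a limit, < 0.0834 h. For the measured compounds named here, neither measured compound therefore gives a number; both sit at the same boundary of the read-out, which is the only thing the two values show together: the limit of < 0.0834 h in this assay, at which 2 of the 2 values shown sit.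

Compound 3 `Cc1cn([C@H]2C[C@H](SSc3ccccc3[N+](=O)[O-])[C@@H](CO)O2)c(=O)[nH]c1=O` keeps the core of compound 2 and changes the disulfide partner: 2-nitrophenyl in place of trichloromethyl on a sulfur. Going by the values given here, no step between measured compounds exists for this change, so the size of the move is not anchored by data. The expectation is for a step upward from compound 2 to compound 3 in this assay, an at least 2.3-fold higher number from compound 2 to compound 3 (0.37 log units; beyond the scatter), beyond the scatter but with wide uncertainty, and with a fair chance that the assay again reports only a limit. Compound 3 is expected to give 0.2 h, in the range 0.05 h to 1.5 h.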

Compound 3, half-life: < 0.0834 h
Compound 3: a limit, no number (the forecaster's own chance of this, stated with the estimate: 40%); at least 2.3-fold (0.37 log units) between middle value and limit.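

In this assay compound 3 returns < 0.0834 h, a limit and not a number. With compound 2 also at a limit, the step from compound 2 to compound 3 cannot be read, and the series stays at one boundary: the limit of < 0.0834 h in this assay, at which 3 of the 3 values shown sit.

The compounds shown leave open how long any of them actually lasts, and whether changing the disulfide partner or the core shifts that at all.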